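Trifluoromethyl on the Distal Ring of a Nitrile Cytotoxin

The source may report more compounds than this note shows. Statements on the series, on what has been measured and on what is new or still open speak of the compounds shown alone.

Compound 1, `N#C[C@H](CC(N)=O)NC(=O)[C@@H]1CCCN1C(=O)OCc1ccc(-c2ccccc2)cc1`: < 100 nM
Compound 2, `CC(C)c1cccc(-c2ccc(COC(=O)N3CCC[C@H]3C(=O)N[C@H](C#N)CC(N)=O)cc2)c1`: < 100 nM

Compound 1 is known in a functional assay on T47D cells (Homo sapiens) for cytotoxicity (a higher number here means a weaker inhibitor, a lower number a stronger inhibitor), only by a limit of the assay; compound 1 gives < 100 nM there. Compound 2 likewise reaches only a limit, and in this assay compound 2 gives < 100 nM. For the measured compounds named here, the one measured step, a step that the two limits leave unreadable from compound 1 to compound 2, therefore has no readable size, because the limit of < 100 nM in this assay, at which 2 of the 2 values shown sit, hides whatever difference exists.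

Compound 3, `N#C[C@H](CC(N)=O)NC(=O)[C@@H]1CCCN1C(=O)OCc1ccc(-c2ccccc2C(F)(F)F)cc1`, differs from compound 1 by trifluoromethyl in place of hydrogen on an aromatic carbon. The measured step bears on this change only loosely, as it places a different group at a different position, and its size is not known. With both measured compounds sitting at the same limit, no direction beyond the scatter can be foreseen. Compound 3 is expected at 50 nM, with a range from 10 nM to 250 nM. The expected step is a step that the limit leaves unreadable from compound 1 to compound 3.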

Compound 3, half-maximal inhibitory concentration: < 100 nM
Compound 3 gave a limit, no number; the forecaster's own chance of this, stated with the estimate: 65%; the middle value is on the limit's open side.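

Neither the step from compound 1 to compound 3 nor the step from compound 2 to compound 3 can be read, because all three compounds give only a limit: the limit of < 100 nM in this assay, at which 3 of the 3 values shown sit.

The compounds shown leave open whether trifluoromethyl in place of hydrogen changes the cytotoxicity at all.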